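Swapping a chloro for piperidinyl on an acylguanidine core

A few compounds are considered here, and "the series" means these few. Any claim that something is new, unique, unknown or untested is made for them only; others in the source may bear on it.

Measured so far:
compound 1 `CCc1cc(Cl)c(S(C)(=O)=O)cc1C(=O)N=C(N)N`: 63 nM
compound 2 `CS(=O)(=O)c1cc(C(=O)N=C(N)N)c(Cl)cc1Cl`: 140 nM
compound 3 `CS(=O)(=O)c1cc(C(=O)N=C(N)N)ccc1Cl`: 380 nM

In a functional assay for inhibition of sodium/hydrogen exchanger (Oryctolagus cuniculus) (on this read-out lower numbers stand for stronger inhibition and higher numbers for weaker inhibition), compound 1 gives the lowest number of the three, with compound 2 giving a 2.2-fold higher number from compound 1 to compound 2 (0.35 log units; beyond the scatter) and compound 3 giving a 6.0-fold higher number from compound 1 to compound 3 (0.78 log units; beyond the scatter). Compound 4 `CCc1cc(N2CCCCC2)c(S(C)(=O)=O)cc1C(=O)N=C(N)N` is not yet measured; it differs from compound 1 in one place: piperidin-1-yl in place of chloro on an aromatic carbon. Among the compounds with values here, none of the measured steps touches this chloro. The steps of a 2.2-fold higher number from compound 1 to compound 2 (0.35 log units; beyond the scatter), a 2.7-fold higher number from compound 2 to compound 3 (0.43 log units; beyond the scatter) and a 6.0-fold higher number from compound 1 to compound 3 (0.78 log units; beyond the scatter) all concern the ethyl group, so they say little about the new change. The expectation for compound 4 is therefore loosely anchored to compound 1, allowing for a modest shift in either direction, given as a 1.6-fold higher number from compound 1 to compound 4 (0.20 log units; within the scatter). Compound 4 is estimated at 100 nM, within 25 nM to 400 nM.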

Compound 4, half-maximal inhibitory concentration: 25 nM
Compound 4: the middle estimate sits 4.0-fold (0.60 log units) above what was measured, and the stated range covers the measured number.
By their numbers in this assay, from the lowest: compound 4; then compound 1; then compound 2; then compound 3.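

Within the data shown here, the earlier steps changed only the ethyl position, so this is the first reading of the position ortho to the methylsulfonyl group. With piperidin-1-yl, 6 heavy atoms in a non-aromatic ring, replacing a single chlorine, this assay shows a 2.5-fold lower number from compound 1 to compound 4 (0.40 log units; beyond the scatter) in the stronger direction, so this much larger group is accepted here and even improves on chloro. Nothing available explains this gain.

From the compounds shown here alone, whether the ring size matters remains open. A smaller amine such as dimethylamino, or a morpholine ring with its added oxygen, could help separate the contributions of ring size and ring atoms.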